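The source may report more compounds than this note shows. Statements on the series, on what has been measured and on what is new or still open speak of the compounds shown alone.

Compound 1 `Cc1ccccc1NS(=O)(=O)c1cccc(NC(=O)NCCCCl)c1` gives 60000 nM in a functional assay on M21 cells (Homo sapiens) for cytotoxicity, read by sulforhodamine B assay, with a stated time of 48 h; a higher number here means a weaker inhibitor, a lower number a stronger inhibitor. Compound 2 `CCc1ccccc1NS(=O)(=O)c1cccc(NC(=O)NCCCCl)c1` reaches only a limit of the assay, > 200000 nM, in this assay. The step of an at least 3.3-fold higher number from compound 1 to compound 2 (0.52 log units; beyond the scatter) already went toward weaker inhibition, and compound 2 stands at the limit of > 200000 nM in this assay, at which 1 of the 2 values shown sits. Compound 3 `CCCc1ccccc1NS(=O)(=O)c1cccc(NC(=O)NCCCCl)c1` carries methyl in place of hydrogen on a saturated chain carbon, two bonds along the chain from an aromatic carbon, the ethyl of compound 2 becoming propyl. Going by the values given here, the single step bearing on it, an at least 3.3-fold higher number from compound 1 to compound 2 (0.52 log units; beyond the scatter), points the same way, so in this assay no gain and most likely another reading at the limit is expected. Compound 3 is estimated at 300000 nM (range 150000 nM to 700000 nM), an expected step that the limit leaves unreadable from compound 2 to compound 3.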

Compound 3, half-maximal inhibitory concentration: 23000 nM
The estimate for compound 3 lay 13-fold (1.12 log units) above the measured number; measured number below the stated range.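

In this assay the methyl added two bonds along the chain from an aromatic carbon reverses the earlier direction, with an at least 8.6-fold lower number from compound 2 to compound 3 (0.93 log units; beyond the scatter) as a bound only, since compound 2 stands at a limit of the assay: the limit of > 200000 nM in this assay, at which 1 of the 3 values shown sits. The series also moves past its methyl member, with a 2.6-fold lower number from compound 1 to compound 3 (0.42 log units; beyond the scatter) and so the number does not follow chain length steadily across compound 1, compound 2 and compound 3, with compound 2 going against any steady fall. As far as these compounds go, whether a butyl chain in this place lowers the number further remains open. So does whether an amine at the chain end would be tolerated.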